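The source may report more compounds than this note shows. Statements on the series, on what has been measured and on what is new or still open speak of the compounds shown alone.

Working notes on the series in an assay on Sf9 cells for inhibition of mitogen-activated protein kinase kinase kinase 14 (Homo sapiens), read by ADP-Glo, with a stated time of 60 min; on this read-out lower numbers stand for stronger inhibition and higher numbers for weaker inhibition.

Compound 1 `Cc1[nH]nc(N)c1-c1ccc(Cl)c(Cl)c1` is reported only as a limit of the assay: in this assay compound 1 gives > 100000 nM, a limit and not a number. Compound 2 `Cc1ccc(-c2c(N)n[nH]c2C)cc1C` is likewise reported as a limit, compound 2 giving > 100000 nM. Compound 3 `Cc1[nH]nc(N)c1-c1cccc(Cl)c1` also stands at the limit, compound 3 giving > 100000 nM. For the measured compounds named here, the one step between measured compounds that differ in one place, a step that the two limits leave unreadable from compound 1 to compound 3, cannot be read in size because both of its ends sit at the limit of > 100000 nM in this assay, at which 3 of the 3 values shown sit. Compound 3 therefore stands nowhere within the numbers; it is known only as a limit.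

Compound 4 `Cc1[nH]nc(N)c1-c1cccc(OC(F)(F)F)c1` has not yet been measured and differs from compound 3 by trifluoromethoxy in place of chloro on an aromatic carbon. Going by the values given here, the only measured step that bears on a change at this position is the one just named, and its size is unreadable. Nothing measured in the series points away from the limit. The step expected in this assay is a number no higher from compound 3 to compound 4 (the limit leaves the size open), none beyond the scatter. Compound 4 is therefore expected to give about 100000 nM in this assay, with a range from 30000 nM to 300000 nM, and most probably to be reported again as a limit.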

Compound 4, half-maximal inhibitory concentration: > 100000 nM
Compound 4 gave a limit, no number; the forecaster's own chance of this, stated with the estimate: 85%; the middle value sits exactly at the limit.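

No new step can be read: compound 4, like compound 3, stands only as a limit of the assay, so the change from compound 3 to compound 4 has no readable size: the limit of > 100000 nM in this assay, at which 4 of the 4 values shown sit.

The compounds shown leave open whether any group on the shared core brings a measurable number in this assay.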